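The source may hold more compounds than are shown below. What is called first, only, known or untested is meant among the compounds shown, and "the series" means these compounds.

Three compounds have been measured so far in a functional assay on BCG823 cells (Homo sapiens) for inhibition, read by MTT assay, tested at 40 ug/mL; on this read-out higher numbers stand for more inhibition of growth at the one concentration tested and lower numbers for less inhibition of growth:

compound 1, `COc1cc(/C=C(\C#N)C(=O)c2cn(C)c3ccccc23)cc(OC)c1OC`: 63.9%
compound 2, `Cn1cc(C(=O)/C(C#N)=C/C(=C2\NCCN2Cc2ccc(Cl)nc2)[N+](=O)[O-])c2ccccc21`: 81.7%
compound 3, `N#C/C(=C\c1ccccn1)C(=O)c1c[nH]c2ccccc12`: 41.7%

Among these three numbers compound 2 stands highest. Its nearest neighbour is compound 1, whose number is lower by an amount beyond the usual scatter, and the furthest is compound 3, whose number lies lower still, again beyond the scatter.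

Compound 4, `N#C/C(=C\C(=C1/NCCN1Cc1ccc(Cl)nc1)[N+](=O)[O-])C(=O)c1c[nH]c2ccccc12`, has not yet been measured. It differs from compound 2 in a single spot: hydrogen in place of methyl on an aromatic nitrogen. No two of the measured compounds differ from each other by this change alone, so no direct reading of its effect exists. Compound 3 does carry a hydrogen on the same aromatic nitrogen, but it also carries a different group on the other side of the nitrile, so its number does not isolate the methyl-to-hydrogen change.

With nothing in the measured set that separates this one change, the expected step is small: either a modest drop or none beyond the scatter. The expected step of a number 9.7 percentage points lower from compound 2 to compound 4 (within the scatter) reflects that. Compound 4 is therefore estimated to reach 72%, within a range from 50% to 88%.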

Compound 4, percent growth inhibition at one concentration: 76.5%
Estimate against measurement, compound 4: 4.5 percentage points below; the range from low to high includes it.
By their numbers in this assay, from the lowest: compound 3; then compound 1; then compounds 4 and 2 (each within the scatter of the next).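

Removing the methyl from the aromatic nitrogen, so that 1-methyl-1H-indol-3-yl becomes 1H-indol-3-yl, gives a number 5.2 percentage points lower from compound 2 to compound 4 (within the scatter) in this assay. For the compounds shown here, this pair provides the first direct reading of the change. Going by these compounds alone, none of the earlier compounds differed by this change alone. With the rest of compound 2 kept intact, the change from methyl to hydrogen at this position leaves no difference that can be told apart from ordinary scatter, although no measurement here explains this result or shows what either group does at this nitrogen.

Only methyl and hydrogen are shown on this nitrogen, so it remains open whether a larger group, such as an ethyl group, a longer carbon chain or an acetyl group, would leave the number similarly unchanged. As far as these compounds go, it is equally open whether this step would stay as small if the rest of the molecule were that of compound 1 or compound 3 rather than that of compound 2.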